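A Second Chloro on the Chlorophenyl Group

The compounds below may be only part of what the source reports. "The series", "measured", "known", "first", "only" and "open" are said of these compounds alone.

Compound 1 `CC(=O)OC/C(=C\c1ccc(Cl)cc1)C(=O)c1ccccc1` gives 4800 nM in a functional assay on WiDr cells (Homo sapiens) for inhibition, read by sulforhodamine B assay, with a stated time of 48 h; on this read-out higher numbers stand for weaker inhibition of growth and lower numbers for stronger inhibition of growth. Compound 2 `CC(=O)OC/C(=C\c1ccc(Cl)cc1)C(=O)c1ccc(Cl)cc1` carries chloro in place of hydrogen (chloro in place of hydrogen on an aromatic carbon), and in this assay compound 2 gives 18000 nM, a step of a 3.8-fold higher number from compound 1 to compound 2 (0.57 log units; beyond the scatter). Compound 3 `CC(=O)OC/C(=C/c1ccc(Cl)cc1)C(=O)c1ccc(Cl)cc1` has the same atoms and bonds as compound 2 and differs only in configuration as drawn (the fact that compounds 2 and 3 differ only in the configuration as drawn); compound 3 gives 17000 nM, a step of a 1.1-fold lower number from compound 2 to compound 3 (0.02 log units; within the scatter). The difference between the cores of compound 1 and compound 3 is not broken down here.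

Compound 4 `CC(=O)OC/C(=C/c1ccc(Cl)cc1Cl)C(=O)c1ccc(Cl)cc1` is not yet measured. It differs from compound 3 by chloro in place of hydrogen on an aromatic carbon. This is the same kind of change as from compound 1 to compound 2, yet the place differs: there the chloro sits para to a large group, here ortho to a large group and meta to a chloro group. Compound 4 is expected to give 28000 nM, a step of a 1.6-fold higher number from compound 3 to compound 4 (0.22 log units; within the scatter). This expectation rests on the earlier step of a 3.8-fold higher number from compound 1 to compound 2 (0.57 log units; beyond the scatter).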

Compound 4, concentration for 50% growth inhibition: 20000 nM
Beside the measured number, compound 4's estimate is 1.4-fold (0.15 log units) above it; low and high end bracket the measured number.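

In this assay, swapping hydrogen for chloro on the core of compound 3, which turns 4-chlorophenyl into 2,4-dichlorophenyl, gives a 1.2-fold higher number from compound 3 to compound 4 (0.07 log units; within the scatter), so this step shows no clear change. The same swap therefore does not carry a fixed size from one core to another in this series: the same change on two cores in this assay, a 3.8-fold higher number (0.57 log units; beyond the scatter) from compound 1 to compound 2 and a 1.2-fold higher number (0.07 log units; within the scatter) from compound 3 to compound 4, 3.2-fold (0.50 log units) apart, beyond the scatter of two such steps. The two swaps differ in both core and place, so these two pairs cannot show which of the two accounts for the gap, and they give no general rule.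

From the compounds shown here alone, it remains open how an amine or a carboxylic acid would compare with chloro at this place. Also open, going by these compounds, is how 2,4-dichlorophenyl would read with the double bond drawn E, as in compound 2.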